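Notes on the step from compound 1 to compound 3

The source may hold more compounds than are shown below. What is called first, only, known or untested is meant among the compounds shown, and "the series" means these compounds.

Compound 1 `c1cnc2c(c1)CCC[C@@H]2N(CCCN1CCNCC1)Cc1cc2ccccc2cn1` gives 74%
Compound 2 `c1ccc2c(c1)CN[C@@H](CN(CCCN1CCN(C3CC3)CC1)[C@H]1CCCc3cccnc31)C2` gives 3%

Both numbers come from an ADME assay on microsomes from liver (Mus musculus) for metabolic stability, read by LC-MS, with a stated time of 10 min, tested at 0.5 uM (on this read-out higher numbers stand for a more stable compound and lower numbers for a less stable compound), and are the only two measured so far. Compound 1 stands highest of the two, and compound 2 lies beyond the usual scatter under it. Compound 3 `c1cnc2c(c1)CCC[C@@H]2N(CCCN1CCNCC1)Cc1nc2ccccc2s1` awaits measurement. It carries 1,3-benzothiazol-2-yl in place of isoquinolin-3-yl on a saturated chain carbon bound to an amine nitrogen.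

Among the measured compounds shown here, no two measured compounds differ in one place only, so no measured step guides this change. A moderate downward step in this assay is expected, though it may not clear the scatter by much. The estimate starts from compound 1 with 74% as its anchor, and the range is kept wide. The expected change is a number 14 percentage points lower from compound 1 to compound 3 (beyond the scatter) on this estimate. For compound 3 the estimated value is 60% within an expected range of 35% to 82% on this read-out.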

Compound 3, percent of the compound remaining: 45%
Compound 3: middle estimate off by 15 percentage points, on the high side, within the range that was stated.
By their numbers in this assay, from the lowest: compound 2; then compound 3; then compound 1.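

In this assay, among the compounds shown here, this is the first pair differing in one place, and it gives a readable step at this position: 1,3-benzothiazol-2-yl in place of isoquinolin-3-yl on a saturated chain carbon bound to an amine nitrogen goes with a number 29 percentage points lower from compound 1 to compound 3 (beyond the scatter). The read-out therefore responds to the aromatic group at this place with the rest of compound 1 held fixed, which compound 2, differing from compound 1 in more than one place, could not show. No measured property bears on this step.

Open, going by these compounds, is whether 1,3-benzoxazol-2-yl, with oxygen in place of sulfur, or a plain phenyl at the same place would read closer to compound 1 or to compound 3. Also open, on these data alone, is whether the step would hold with a longer chain in the shared core.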